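The compounds below may be only part of what the source reports. "The series", "measured", "known", "first", "only" and "open" are said of these compounds alone.

Compound 1 `CC(=O)c1ccc2c(c1)N(C1=CCCC1=O)CC(C)(C)S2` and compound 2 `CC1(C)CSc2ccc(C(F)(F)F)cc2N1C1=CCCC1=O` share one core and differ only in the group on the aromatic ring. In a functional assay on aorta (Rattus norvegicus, strain Wistar) (on this read-out higher numbers stand for larger maximal responses and lower numbers for smaller maximal responses), compound 1 gives 88%, and in this assay compound 2 gives 89%. Compound 1 therefore holds the smaller of the two numbers shown so far, but the gap to compound 2 lies within the usual scatter of such measurements, so the two cannot be told apart on these data.

Compound 3 `CCc1ccc2c(c1)N(C1=CCCC1=O)CC(C)(C)S2` keeps the same core and differs from compound 1 in one place: ethyl in place of acetyl on an aromatic carbon. Going by the values given here, no step between two measured compounds is available to guide this change. What the two measured compounds do show is that two rather different groups in that place, the acetyl of compound 1 and the trifluoromethyl of compound 2, give nearly the same maximal response in this assay. On that basis no step beyond the scatter is expected from compound 1 to compound 3. Compound 3 is expected to give about 86%, with an estimated range from 72% to 98%. The expected step of a number 2 percentage points lower from compound 1 to compound 3 (within the scatter) is thus estimated to remain within the scatter.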

Compound 3, largest response reached (Emax), in percent of the reference or control that the assay uses: 97%
Compound 3: middle estimate off by 11 percentage points, on the low side; the measured number falls inside the stated range.
By their numbers in this assay, from the lowest: compounds 1, 2 and 3 (each within the scatter of the next).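

Ethyl in place of acetyl on this aromatic carbon gives a number 9 percentage points higher from compound 1 to compound 3 (within the scatter) in this assay, so this single change leaves the two compounds indistinguishable on this read-out. The change removes the acetyl's oxygen, with its hydrogen-bond acceptor and its double bond outside aromatic rings, and puts a group of carbon alone in that place, yet this gives no step beyond the scatter; on these compounds, a large maximal response at this position therefore does not depend on that acceptor. Nothing measured alongside these numbers bears on why the response stays at this level.

What remains open is whether any group on this aromatic carbon can move the maximal response beyond the scatter, since the groups shown so far are only acetyl, trifluoromethyl and ethyl. An amine, a carboxylic acid or a longer chain such as butyl in that place would test this, and the compounds shown give no indication of how any of them would behave in this assay.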